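Swapping the dimethoxyphenyl of compound 1 for a chlorophenyl

A few compounds are considered here, and "the series" means these few. Any claim that something is new, unique, unknown or untested is made for them only; others in the source may bear on it.

Compound 1 `COc1ccc(-c2nc(C)c(C(=O)CSc3nc(-c4ccc(OC)c(OC)c4)c(C#N)c(=O)[nH]3)s2)cc1` was tested in a functional assay on U-87MG ATCC cells for antiproliferative activity against U-87 MG (Homo sapiens), read by MTT assay, with a stated time of 48 h, tested at 5 uM (a lower number here means a stronger effect, a higher number a weaker effect of the compound at the concentration tested), where compound 1 gives 81.2%. Among the three measured compounds it stands second highest: compound 2 `COc1ccc(-c2nc(SCC(=O)c3sc(-c4ccccc4)nc3C)[nH]c(=O)c2C#N)cc1OC` gives 80.8%, and the step of a number 0.4 percentage points lower from compound 1 to compound 2 (within the scatter) lies within the usual scatter, while compound 3 `COc1ccc(-c2nc(SCC(=O)c3sc(-c4ccc(Cl)cc4)nc3C)[nH]c(=O)c2C#N)cc1OC` gives 93.4%, a difference of a number 12.2 percentage points higher from compound 1 to compound 3 (beyond the scatter) beyond it.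

Compound 4 `COc1ccc(-c2nc(C)c(C(=O)CSc3nc(-c4cccc(Cl)c4)c(C#N)c(=O)[nH]3)s2)cc1` has not yet been measured. It differs from compound 1 in one place: 3-chlorophenyl in place of 3,4-dimethoxyphenyl on an aromatic carbon. Among the measured compounds shown here, none of the measured steps changes this same ring, so they bear only loosely on the new compound. The two steps that introduce a chlorine, a number 12.2 percentage points higher from compound 1 to compound 3 (beyond the scatter) and a number 12.6 percentage points higher from compound 2 to compound 3 (beyond the scatter), both raised the number modestly, on a different aryl ring of the shared core. A similar, modest rise is therefore the most plausible expectation, though the change is larger here, as the two methoxy groups also leave.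

Compound 4 is estimated to give 86%, in a range from 74% to 98%, meaning an expected step of a number 4.8 percentage points higher from compound 1 to compound 4 (within the scatter).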

Compound 4, a percentage reported as activity, at one concentration (the size of the read-out at that concentration, not a potency): 95.7%
For compound 4 the middle estimate is 9.7 percentage points below the measured one, within the range that was stated.
By their numbers in this assay, from the lowest: compounds 2 and 1 (each within the scatter of the next); then compounds 3 and 4 (each within the scatter of the next).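

In this assay, among the compounds shown here, the aryl group next to the ring nitrogen and ortho to a cyano group also affects the result, a position the earlier compounds left unchanged: 3-chlorophenyl in place of 3,4-dimethoxyphenyl gives a number 14.5 percentage points higher from compound 1 to compound 4 (beyond the scatter) and therefore a weaker effect at the concentration tested. Together with a number 12.2 percentage points higher from compound 1 to compound 3 (beyond the scatter) on the other aryl ring, this means that both changes from compound 1 that bring in a chlorine weaken the effect, and no compound shown goes against this. No measurement available here explains the rise.

Because the two methoxy groups leave as the chlorine enters, the compounds shown cannot separate the effect of losing the methoxy groups from that of adding the chlorine. An unsubstituted phenyl, a 3-methoxyphenyl or an aminophenyl at this position remains an open case.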